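The source may report more compounds than this note shows. Statements on the series, on what has been measured and on what is new or still open speak of the compounds shown alone.

In a toxicity assay on Vero cells (Chlorocebus sabaeus) for inhibition (on this read-out lower numbers stand for an effect already at smaller amounts and higher numbers for an effect only at larger amounts of compound), compound 1 `COc1cccc(NC(=O)c2nnn(Cc3ccc(C(C)C)cc3)c2N)c1` gives > 50100 nM, which is a limit and not a number. Compound 2 `COc1cccc(NC(=O)c2nnn(Cc3ccccc3)c2N)c1`, which carries hydrogen in place of isopropyl on an aromatic carbon, gives > 50100 nM, also a limit. Both compounds therefore sit at the limit of > 50100 nM in this assay, at which 2 of the 2 values shown sit, so compound 1 has no exact position on this scale.

Compound 3 `COc1cccc(NC(=O)c2nnn(C(CO)c3ccc(C(C)C)cc3)c2N)c1` differs from compound 1 by hydroxymethyl in place of hydrogen on a saturated chain carbon bound to an aromatic carbon and an aromatic nitrogen. For the measured compounds named here, the only measured step, a step that the two limits leave unreadable from compound 1 to compound 2, involves a different change and gives no size to carry over. No step beyond the usual scatter is therefore expected in this assay, and no direction is favoured. The expected step is a number no higher from compound 1 to compound 3 (the limit leaves the size open). The estimate for compound 3 is 50100 nM, within an expected range of 20000 nM to 100000 nM.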

Compound 3, half-maximal effective concentration: 12600 nM
Estimate against measurement, compound 3: 4.0-fold (0.60 log units) above, outside the stated range (below it).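

In this assay, this saturated chain carbon bound to an aromatic carbon and an aromatic nitrogen turns out not to be a silent place: hydroxymethyl in place of hydrogen gives an at least 3.9-fold lower number from compound 1 to compound 3 (0.59 log units; beyond the scatter). The true step may be larger, since the starting point is a limit, but a lower number here means that the effect on the cells appears at smaller amounts of compound. Compound 3 is also the only one of the three with an exact position on this scale, while compound 1 and compound 2 stay at a limit: the limit of > 50100 nM in this assay, at which 2 of the 3 values shown sit.

From the compounds shown here alone, it remains open whether the oxygen of hydroxymethyl matters or the added carbon alone is enough, which a plain methyl, an aminomethyl or a carboxylic acid at this carbon could help to separate. Going by these compounds, it is also open whether the same change has a similar effect on compound 2, which has hydrogen in place of isopropyl.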